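From 2,4-dimethylphenyl to 2-methoxyphenyl on compound 3

A few compounds are considered here, and "the series" means these few. Any claim that something is new, unique, unknown or untested is made for them only; others in the source may bear on it.

In a functional assay on A549 cells (Homo sapiens) for antiproliferative activity, read by MTT assay (a higher number here means a weaker inhibitor, a lower number a stronger inhibitor), compound 1 (`COc1cc2c(Oc3ccc(NC(=O)Nc4cccc(C)c4)cc3)ccnc2cc1OCCCCCCC(=O)NO`) gives 2010 nM, compound 2 (`COc1cc2c(Oc3ccc(NC(=O)Nc4ccc(OC(F)(F)F)cc4)cc3)ccnc2cc1OCCCCCCC(=O)NO`) gives 3130 nM and compound 3 (`COc1cc2c(Oc3ccc(NC(=O)Nc4ccc(C)cc4C)cc3)ccnc2cc1OCCCCCCC(=O)NO`) gives 5490 nM. Compound 3 stands clearly apart from compound 1 only, with a 2.7-fold higher number from compound 1 to compound 3 (0.44 log units; beyond the scatter). Its gap to compound 2 is smaller, at a 1.8-fold higher number from compound 2 to compound 3 (0.24 log units; within the scatter).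

Compound 4 (`COc1ccccc1NC(=O)Nc1ccc(Oc2ccnc3cc(OCCCCCCC(=O)NO)c(OC)cc23)cc1`) has 2-methoxyphenyl in place of 2,4-dimethylphenyl on an amide-type nitrogen. The entering group counts one hydrogen-bond acceptor, and the leaving group counts none. The three measured steps all change the group at this same place. Besides the two above, there is a 1.6-fold higher number from compound 1 to compound 2 (0.19 log units; within the scatter). So three different groups here have produced only small to modest steps, although none of them is 2-methoxyphenyl. A step beyond the scatter is therefore not expected, and compound 4 should land among the three measured numbers. The expected change is a 1.7-fold lower number from compound 3 to compound 4 (0.22 log units; within the scatter). For compound 4 the estimated value is 3300 nM, with an expected range of 1500 nM to 7200 nM.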

Compound 4, half-maximal inhibitory concentration: 16200 nM
Estimate against measurement, compound 4: 4.9-fold (0.69 log units) below; measured number above the stated range.
By their numbers in this assay, from the lowest: compounds 1, 2 and 3 (each within the scatter of the next, the first and the last beyond it); then compound 4.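

In this assay, going by these compounds alone, compound 4 has the highest number of the four, and the place proves more sensitive than the earlier steps suggested, with a 3.0-fold higher number from compound 3 to compound 4 (0.47 log units; beyond the scatter) and a 5.2-fold higher number from compound 2 to compound 4 (0.71 log units; beyond the scatter) and also an 8.1-fold higher number from compound 1 to compound 4 (0.91 log units; beyond the scatter) as the new steps. The step from 2,4-dimethylphenyl to 2-methoxyphenyl keeps the count of 8 heavy atoms and the single aromatic ring, yet it still lies beyond the scatter, so the heavy-atom count alone does not settle the result on this amide-type nitrogen. The change swaps carbon for oxygen in the group and adds one hydrogen-bond acceptor.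

On these data alone, whether the higher number follows the methoxy group itself or where that group sits stays open, and a 2-methylphenyl or a 4-methoxyphenyl group on the same nitrogen would help to separate the two. Nothing available explains why this change weakens compound 4.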